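Swapping a Hydroxybenzyl Arm for a Fluorophenylethyl Arm

The source may hold more compounds than are shown below. What is called first, only, known or untested is meant among the compounds shown, and "the series" means these compounds.

Compound 3 `CCc1ccc2[nH]c(=O)c(CN(Cc3ccc(O)cc3)Cc3ccc(C(C)(C)C)cc3)cc2c1` reaches only a limit in a toxicity assay on MDCK cells (Canis lupus familiaris) for cytotoxicity, read by crystal violet staining, with a stated time of 48 h (a lower number here means that less compound is tolerated, a higher number that more compound is tolerated), reading > 10000 nM. Compound 1 `CCc1ccc2[nH]c(=O)c(CN(Cc3ccc(C(C)(C)C)cc3)Cc3ccc(F)c(F)c3)cc2c1` likewise stops at a limit, > 33000 nM. Compound 2 `Cc1ccc2[nH]c(=O)c(CN(Cc3ccc(O)cc3)Cc3ccc(C(C)(C)C)cc3)cc2c1` gives a number, 4900 nM. The untested compound 4 `CCc1ccc2[nH]c(=O)c(CN(Cc3ccc(C(C)(C)C)cc3)C(C)c3ccc(F)cc3)cc2c1` differs from compound 3 by 1-(4-fluorophenyl)ethyl in place of 4-hydroxybenzyl on an amine nitrogen. Among the measured compounds shown here, two measured steps touch this change. an at least 2.0-fold higher number from compound 2 to compound 3 (0.30 log units; that floor lies within the scatter) adds a methyl and raises the tolerated concentration as far as the limit of > 10000 nM in this assay, at which 1 of the 3 values shown sits, allows it to be seen. a step that the two limits leave unreadable from compound 1 to compound 3 cannot be sized, since both values are limits, the limit of > 33000 nM in this assay, at which 1 of the 3 values shown sits, among them. The 1-(4-fluorophenyl)ethyl group entering compound 4 resembles the arm of compound 1, which gave only a limit. Compound 4 is therefore expected around 30000 nM, probably reported as a limit, within 10000 nM to 100000 nM. That expected step is a step that the limit leaves unreadable from compound 3 to compound 4.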

Compound 4, half-maximal cytotoxic concentration: 2800 nM
Compound 4: middle estimate off by 11-fold (1.03 log units), on the high side; the whole stated range lies above it.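

At this amine nitrogen the choice of arm changes the result in this assay: 1-(4-fluorophenyl)ethyl in place of 4-hydroxybenzyl gives an at least 3.5-fold lower number from compound 3 to compound 4 (0.55 log units; beyond the scatter), so less compound is tolerated. In place of 3,4-difluorobenzyl, the same group gives an at least 11-fold lower number from compound 1 to compound 4 (1.07 log units; beyond the scatter). Each step starts from a limit, so each size is only a floor.

The compounds shown do not separate the effect of the methyl on the new arm from that of its fluorine. A 4-fluorobenzyl or 1-(4-hydroxyphenyl)ethyl arm on the same nitrogen would separate them.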